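The compounds below may be only part of what the source reports. "The series", "measured", "known", "first", "only" and "open" are said of these compounds alone.

Measured so far:
compound 1 `COc1cc(-c2nn(-c3cccc(NC(=O)Nc4cc(C(F)(F)F)cc(C(F)(F)F)c4)c3)cc2-c2ccncc2)ccc1Cl` — 2570 nM
compound 2 `COc1cc(-c2nn(-c3cccc(NC(=O)Nc4ccc(Cl)c(Cl)c4)c3)cc2-c2ccncc2)ccc1Cl` — > 50000 nM

In a functional assay on SK-OV-3 cells (Homo sapiens) for inhibition, read by sulforhodamine B assay, with a stated time of 48 h (on this read-out lower numbers stand for stronger inhibition of growth and higher numbers for weaker inhibition of growth), compound 1 gives 2570 nM. For compound 2 the read-out is a limit of the assay and not a number, > 50000 nM. Compound 2 therefore sits at the limit of > 50000 nM in this assay, at which 1 of the 2 values shown sits, the weak end of the numbers shown. Compound 3 `COc1cc(-c2nn(-c3cccc(NC(=O)Nc4cccc(C(F)(F)F)c4)c3)cc2-c2ccncc2)ccc1Cl` is still to be measured. The change from compound 2 to compound 3 is 3-(trifluoromethyl)phenyl in place of 3,4-dichlorophenyl on an amide-type nitrogen. For the measured compounds named here, no measured step covers this change, so the size of the step is open. The expected step is an at least 3.3-fold lower number from compound 2 to compound 3 (0.52 log units; beyond the scatter), toward stronger inhibition. Compound 3 is estimated at 15000 nM, with a range from 4000 nM to 50000 nM.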

Compound 3, concentration for total growth inhibition: > 50000 nM
Compound 3: no number, only a limit; the forecaster's own chance of this, stated with the estimate: 35%; middle value at least 3.3-fold (0.52 log units) from the limit.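

In this assay, hydrogen in place of trifluoromethyl on an aromatic carbon gives an at least 19-fold higher number from compound 1 to compound 3 (1.28 log units; beyond the scatter), so with this core the growth inhibition seen for compound 1 does not survive the loss of that one trifluoromethyl. Neither 3,4-dichlorophenyl nor 3-(trifluoromethyl)phenyl on the amide-type nitrogen gives a value off the limit, so the step between them cannot be read: the limit of > 50000 nM in this assay, at which 2 of the 3 values shown sit.

Still open, on these data alone, is whether the second trifluoromethyl is specifically required, or whether a nitrile or a tert-butyl group on that aromatic carbon would also give a measurable value.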